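A few compounds are considered here, and "the series" means these few. Any claim that something is new, unique, unknown or untested is made for them only; others in the source may bear on it.

Measured so far in a functional assay on GBM3 cells (Homo sapiens) for antiproliferative activity, read by WST assay, with a stated time of 72 h; on this read-out higher numbers stand for weaker inhibition and lower numbers for stronger inhibition:
- Compound 1 `O=C(Nc1cc2ncncc2cc1OCc1ccc(Cl)cc1)Nc1cccc2ccccc12`: 7700 nM
- Compound 2 `O=C(Nc1cc2ncncc2cc1OCc1ccc(F)cc1)Nc1cccc2ccccc12`: 8300 nM
- Compound 3 `O=C(Nc1cc2ncncc2cc1OCc1cccc(F)c1)Nc1cccc2ccccc12`: 1200 nM

Compound 3 gives the lowest number of the three in this assay, at 1200 nM. Compound 4 `O=C(Nc1cc2ncncc2cc1OCc1ccccc1Cl)Nc1cccc2ccccc12` carries 2-chlorophenyl in place of 3-fluorophenyl on a saturated chain carbon bound to an oxygen on an aromatic ring.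

Two measured changes of this same group bear on it: a 6.4-fold lower number from compound 1 to compound 3 (0.81 log units; beyond the scatter) and a 6.9-fold lower number from compound 2 to compound 3 (0.84 log units; beyond the scatter). Both are modest, and both lead to compound 3. The third, a 1.1-fold higher number from compound 1 to compound 2 (0.03 log units; within the scatter), shows that exchanging the halogen on the same ring made no measurable difference. Among the compounds with values here, no measured compound carries 2-chlorophenyl, so the size of this step remains uncertain. A modest rise in the number is expected, probably smaller than those two steps.

The estimate amounts to a 2.5-fold higher number from compound 3 to compound 4 (0.40 log units; beyond the scatter), an expected loss of inhibition. For compound 4 the estimated value is 3000 nM, with an expected range of 1000 nM to 9000 nM.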

Compound 4, half-maximal inhibitory concentration: 2700 nM
For compound 4 the middle estimate is 1.1-fold (0.05 log units) above the measured one; measured number inside the range.
By their numbers in this assay, from the lowest: compound 3; then compound 4; then compounds 1 and 2 (each within the scatter of the next).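

In this assay, moving the chlorine alone, with 2-chlorophenyl in place of 4-chlorophenyl, gives a 2.9-fold lower number from compound 1 to compound 4 (0.46 log units; beyond the scatter), and the same group in place of 4-fluorophenyl gives a 3.1-fold lower number from compound 2 to compound 4 (0.49 log units; beyond the scatter), so where the halogen sits on this ring changes the number, whereas exchanging the halogen on the 4-substituted ring did not. The 2-chlorophenyl group still does not match 3-fluorophenyl, with a 2.3-fold higher number from compound 3 to compound 4 (0.35 log units; beyond the scatter), which leaves compound 3 with the lowest number of the four. Nothing available here accounts for these differences.

The compounds shown leave open how 3-chlorophenyl and 2-fluorophenyl would compare, and these would separate the effect of the halogen from that of its place on the ring. Also open, as far as these compounds go, is whether unsubstituted phenyl, or a ring bearing a methoxy group or an amine, would fall in the same range.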